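Replacing the pyrrolyl group: an estimate for compound 4

The source may report more compounds than this note shows. Statements on the series, on what has been measured and on what is new or still open speak of the compounds shown alone.

Measured compounds:
Compound 1, `CC(=O)c1ccc2c(c1)C(n1ccccc1=O)=CC(C)(C)O2`, gives 7.37 in a functional assay (aorta) with Rattus norvegicus as the target; a lower number here means a less potent compound, a higher number a more potent compound, by a factor of ten per unit of this negative logarithm.
Compound 2, `CC1(C)C=C(n2ccccc2=O)c2cc(C(=O)c3ccccc3)ccc2O1`, gives 6.61 in this assay.
Compound 3, `Cc1ccc(C)n1-c1ccc2c(c1)C(n1ccccc1=O)=CC(C)(C)O2`, gives 7.27 in this assay.

Compound 3 stands second highest of the three; its gap to compound 1 is within the scatter, while it lies a number 0.66 log units higher from compound 2 to compound 3 (beyond the scatter). Compound 4, `CC1(C)C=C(n2ccccc2=O)c2cc(OS(=O)(=O)F)ccc2O1`, has not been measured. The change is (fluorosulfonyl)oxy in place of 2,5-dimethyl-1H-pyrrol-1-yl on an aromatic carbon. Among the measured compounds shown here, no measured step involves this group. The step of a number 0.10 log units lower from compound 1 to compound 3 (within the scatter) shows that exchanging groups at this position can leave the number almost unchanged, whereas a number 0.76 log units lower from compound 1 to compound 2 (beyond the scatter) shows a modest loss is possible. A modest decrease beyond the scatter, a number 0.47 log units lower from compound 3 to compound 4 (beyond the scatter), is therefore expected. Compound 4 is estimated at 6.8, in a range from 6 to 7.5.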

Compound 4, logarithm of the reciprocal of the active concentration, log(1/C): 7.95
For compound 4 the middle estimate is 1.15 log units below the measured one; measured number above the stated range.
By their numbers in this assay, from the lowest: compound 2; then compounds 3 and 1 (each within the scatter of the next); then compound 4.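

At this aromatic carbon in this assay, (fluorosulfonyl)oxy, a group with no ring, exceeds all three earlier groups: 2,5-dimethyl-1H-pyrrol-1-yl (a number 0.68 log units higher from compound 3 to compound 4 (beyond the scatter)), acetyl (a number 0.58 log units higher from compound 1 to compound 4 (beyond the scatter)) and benzoyl (a number 1.34 log units higher from compound 2 to compound 4 (beyond the scatter)). Among the compounds shown here, the earlier compounds showed only that exchanging groups here could hold the number or lower it, whereas this change shows it can also rise. Nothing available explains this gain. From the compounds shown here alone, what an amine, a methoxy group or a methylsulfonyl group on this aromatic carbon would give remains open, as does whether the fluorine of the (fluorosulfonyl)oxy group matters to the number.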